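Assigning the ring stereocentre: from compound 2 to compound 3

This account rests on a few compounds, and the source may have more. Where it says the series, first, only, none or still open, it means among the compounds named here.

Compound 1 `C[C@H]1CC/C(=N\Nc2ccccc2)c2ncc(C(=O)O)c(=O)n21` carries a configured stereocentre at the saturated ring carbon; in a functional assay on the whole organism with Rattus norvegicus as the target (on this read-out higher numbers stand for an effect only at larger amounts of compound and lower numbers for an effect already at smaller amounts), compound 1 gives 0.3 umol/kg. Compound 2 `CC1CC/C(=N\Nc2ccccc2)c2ncc(/C=C/C(=O)O)c(=O)n21` is drawn without a configuration at that centre, and in this assay compound 2 gives 0.27 umol/kg. Of the two numbers shown, the one for compound 2 is the smaller, yet its gap to compound 1 lies within the scatter, so the two are read as alike and no order is claimed.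

Compound 3 `C[C@H]1CC/C(=N\Nc2ccccc2)c2ncc(/C=C/C(=O)O)c(=O)n21` is the next member. Its difference from compound 2 is the two compounds have the same atoms and bonds; at least one stereo element is drawn with a configuration in one of them and without one in the other: 1 of 3 stereo elements differ; a stereocentre at a saturated ring carbon is drawn without a configuration in compound 2 and S in compound 3. Among the measured compounds shown here, no step between measured compounds covers this kind of change, so the expectation rests on compound 1, whose value 0.3 umol/kg shows that the S-configured centre goes with a number of this size in this assay. The step from compound 2 to compound 3 is expected to be small, at most a shift towards a lower number, a 1.4-fold lower number from compound 2 to compound 3 (0.13 log units; within the scatter). For compound 3 the estimate in this assay is 0.2 umol/kg, with a range from 0.1 umol/kg to 0.5 umol/kg.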

Compound 3, dose for 50% inhibition: 0.15 umol/kg
Compound 3: middle estimate off by 1.3-fold (0.12 log units), on the high side, within the range that was stated.
By their numbers in this assay, from the lowest: compounds 3, 2 and 1 (each within the scatter of the next).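

In this assay, drawing the ring stereocentre as S gives a 1.8-fold lower number from compound 2 to compound 3 (0.26 log units; within the scatter), so on this read-out defining the centre does not set compound 3 apart from compound 2. Among the compounds shown here, with the S centre the same in both compounds, the acid side chain can now be read on its own for the first time, and 2-carboxyethenyl in place of carboxy on an aromatic carbon gives a 2.0-fold lower number from compound 1 to compound 3 (0.30 log units; within the scatter), so the longer unsaturated acid chain and the directly attached acid are not told apart in this assay. The stereo comparison remains a weak one, since a centre drawn without a configuration does not amount to a direct comparison of S with R, and any reading of this pair has to be limited accordingly, because of the following: the fact that one of compounds 2 and 3 is drawn with a defined configuration and the other without, at the place where they differ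

As far as these compounds go, what the R configuration at the saturated ring carbon would give stays open, and with it whether this centre matters at all on this read-out. Also open, from the compounds shown here alone, is whether the acid on the aromatic carbon can give way to a primary amide, a tetrazole or a longer chain ending in a carboxylic acid.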